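The source may hold more compounds than are shown below. What is called first, only, known or untested is meant among the compounds shown, and "the series" means these compounds.

Of the compounds shown here, three sharing one core have been measured in a functional assay on MCF7 cells (Homo sapiens) for antiproliferative activity, read by sulforhodamine B assay, with a stated time of 48 h; a lower number here means a stronger inhibitor, a higher number a weaker inhibitor. Compound 1 `COc1ccc(C[C@@H](O)/C=C/C=C/C(=O)N2CCCCC2)cc1OC` gives 39500 nM. Compound 3 `COc1ccc(C[C@@H](O)/C=C/C=C/C(=O)NCc2ccccc2)cc1OC` gives 33600 nM, and the measured change, benzylamino in place of piperidin-1-yl on a carbonyl carbon, amounts to a 1.2-fold lower number from compound 1 to compound 3 (0.07 log units; within the scatter). Compound 2 `COc1ccc(C[C@@H](O)/C=C/C=C/C(=O)N2CCN(c3ccccc3)CC2)cc1OC` gives 12000 nM, the lowest of the three numbers, and its gaps to both of the others lie beyond the scatter.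

Compound 4 `COc1ccc(C[C@@H](O)/C=C/C=C/C(=O)N2CCN(c3ncccn3)CC2)cc1OC` departs from compound 2 in one place, with pyrimidin-2-yl in place of phenyl on an amine nitrogen in a ring. For the measured compounds named here, no measured step covers this exchange. The only one available, a 1.2-fold lower number from compound 1 to compound 3 (0.07 log units; within the scatter), lies at a different place and within the scatter, so it offers little guidance on size. Going by the values given here, the values show only that compound 2, at 12000 nM, stands apart from compound 3, at 33600 nM. With the phenyl gone, a small drift back toward the higher numbers seems the more likely outcome, though the data cannot settle its direction firmly. The expected change is a 1.5-fold higher number from compound 2 to compound 4 (0.18 log units; within the scatter). For compound 4 the estimated value in this assay is 18000 nM, with an expected range from 7000 nM to 40000 nM.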

Compound 4, half-maximal inhibitory concentration: 14700 nM
Beside the measured number, compound 4's estimate is 1.2-fold (0.09 log units) above it; low and high end bracket the measured number.
By their numbers in this assay, from the lowest: compounds 2 and 4 (each within the scatter of the next); then compounds 3 and 1 (each within the scatter of the next).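

In this assay, the exchange of phenyl for pyrimidin-2-yl amounts to a 1.2-fold higher number from compound 2 to compound 4 (0.09 log units; within the scatter), so this place on an amine nitrogen in a ring accepts the new group with no change that can be told from the scatter. For the compounds shown here, this is the first measured step at this place, and it shows that an aromatic ring of carbon only can give way to one with 2 hetero atoms, with the hydrogen-bond acceptors of the group going from 0 to 2, while the number stays within the scatter. Nothing measured here speaks to why the two groups read alike.

As far as these compounds go, it remains open whether the aromatic ring on this nitrogen matters at all, since a methyl, an acetyl or a cyclohexyl group in its place, or a phenyl carrying a chlorine or a methoxy group, could read quite differently. From the compounds shown here alone, the shared core also stays fixed throughout, so what a ketone in place of the hydroxyl group, or a shorter chain leading to the amide carbonyl, would do to these numbers also remains unknown.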